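The source may hold more compounds than are shown below. What is called first, only, known or untested is meant among the compounds shown, and "the series" means these compounds.

Compound 1 `COc1ccc(F)cc1CNCCCNc1ccnc2cc(C3CCCCC3)ccc12` was tested in a physicochemical assay for solubility, with a stated time of 18 h, at pH 7.4 (a lower number here means a less soluble compound, a higher number a more soluble compound), where compound 1 gives 4200 nM. Two further compounds were run alongside it: compound 2 `Fc1ccc(Oc2ccc3c(NCCCNCc4ccco4)ccnc3c2)cc1`, which in this assay gives 14500 nM, and compound 3 `COc1cccc(CNCCCNc2ccnc3cc(Oc4ccccc4)ccc23)c1O`, which gives 14500 nM. Of these three numbers, that of compound 1 is the lowest, and both other compounds lie beyond the usual scatter from it. Compound 4 `COc1ccc(F)cc1CNCCCNc1ccnc2cc(Cc3ccccc3)ccc12` has not yet been measured; it differs from compound 1 only by benzyl in place of cyclohexyl on an aromatic carbon. Within the data shown here, no directly comparable step between measured compounds exists, so the size of the change has to be estimated. Compound 2 and compound 3 show that this part of the shared core can carry other groups with higher numbers, but each of them also differs elsewhere, so they give no direct measure. Compound 4 is expected to show a modest rise, a 1.7-fold higher number from compound 1 to compound 4 (0.22 log units; within the scatter), near the edge of the scatter. The estimate for compound 4 is 7000 nM, within a range from 2500 nM to 20000 nM.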

Compound 4, solubility: 4200 nM
Compound 4: middle estimate off by 1.7-fold (0.22 log units), on the high side, and the stated range covers the measured number.
By their numbers in this assay, from the lowest: compounds 1 and 4 (each within the scatter of the next); then compounds 2 and 3 (each within the scatter of the next).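

In this assay, among these compounds, benzyl in place of cyclohexyl on this aromatic carbon gives no change at the digits printed from compound 1 to compound 4 (within the scatter), the first step that reads this position with the rest of the molecule held fixed. Across this one pair, a six-membered non-aromatic ring of carbon only and a benzyl group carrying an aromatic ring give numbers that cannot be told apart. Nothing measured here bears on why the two groups read alike.

The compounds shown leave open whether a group with a hydrogen-bond donor or acceptor at this carbon, such as an amine, a carboxylic acid or a morpholine, would move the number beyond the scatter. They also leave open whether benzyl and cyclohexyl would still read alike on a compound that differs from compound 1 elsewhere.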